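The source may report more compounds than this note shows. Statements on the series, on what has been measured and on what is new or still open speak of the compounds shown alone.

Measured compounds:
compound 1 `Cc1nc2c(OCc3ccccc3)cccn2c1C#N` — 25%
compound 2 `Cc1nc2c(OCc3ccccc3)cccn2c1CO` — 99%

Going by the values given here, in a functional assay on the whole organism with Rattus norvegicus as the target, with a stated time of 4 h, at a dose of 40 mg/kg by the intraperitoneal route (on this read-out higher numbers stand for more inhibition at the one dose given (going by the name of the read-out) and lower numbers for less inhibition), compound 2 gives 99%, the higher of the two numbers; compound 1 gives 25%, and the only measured step, a number 74 percentage points higher from compound 1 to compound 2 (beyond the scatter), shows how much the hydroxymethyl in place of cyano raised the read-out. Compound 3 `CCOCc1c(C)nc2c(OCc3ccccc3)cccn12` differs from compound 2 by ethyl in place of hydrogen on an oxygen on a saturated carbon, so that the hydroxy becomes an ethoxy and the hydroxymethyl an ethoxymethyl. Among the compounds with values here, no measured step concerns this change; the one step that exists shows only that the hydroxymethyl matters, without telling whether its hydrogen is needed. Since compound 2 already lies near the top of the scale, any step beyond the scatter can only go downward. The expected step is a number 29 percentage points lower from compound 2 to compound 3 (beyond the scatter), a moderate loss. Compound 3 is therefore estimated at 70%, within a range from 30% to 100%.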

Compound 3, a percentage reported as inhibition, in the whole organism at one dose (the size of the read-out at that dose, not a potency): 84%
Compound 3: the middle estimate sits 14 percentage points below what was measured; measured number inside the range.
By their numbers in this assay, from the lowest: compound 1; then compound 3; then compound 2.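

In this assay, turning the hydroxy into an ethoxy gives a number 15 percentage points lower from compound 2 to compound 3 (beyond the scatter), so the read-out at this one dose stays high with ethyl in place of the hydrogen on that oxygen, although part of it is lost. Measured against the nitrile, the ethoxymethyl group still gives a number 59 percentage points higher from compound 1 to compound 3 (beyond the scatter), which shows that most of the large gain over compound 1 survives without the free hydroxy. Nothing at hand explains why either step has its size.

The compounds shown leave open whether a longer chain on this oxygen, such as butyl, would lower the read-out further or leave it about where it stands. They also leave open how an amine or a carboxylic acid at this place would compare with the hydroxymethyl and ethoxymethyl groups.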